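Working notes: acetyl in place of hydroxymethyl on the chain

The source may report more compounds than this note shows. Statements on the series, on what has been measured and on what is new or still open speak of the compounds shown alone.

Compound 1 `CCCn1cnc2c1c(=O)n(C)c(=O)n2CCC`: 5000 nM
Compound 2 `CCCn1c(=O)n(C)c(=O)c2c1ncn2CCCO`: 22600 nM

Both values come from a functional assay (trachea) with Cavia porcellus as the target; on this read-out lower numbers stand for an effect already at smaller amounts and higher numbers for an effect only at larger amounts of compound. Among the compounds with values here, compound 2 has the higher of the two numbers, and the gap to its only neighbour is a 4.5-fold higher number from compound 1 to compound 2 (0.66 log units; beyond the scatter). That step, hydroxy in place of hydrogen on a saturated chain carbon, is modest but beyond the scatter.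

Compound 3 `CCCn1c(=O)n(C)c(=O)c2c1ncn2CCC(C)=O` has not yet been measured. The change leading to it is acetyl in place of hydroxymethyl on a saturated chain carbon, two bonds along the chain from an aromatic nitrogen. The same difference reads as 3-hydroxypropyl to 2-acetylethyl.

Within the data shown here, only one measured step bears on this change, and it covers a different replacement, so the support is thin. Compound 3 lacks the hydroxy, as compound 1 does, so part of a 4.5-fold higher number from compound 1 to compound 2 (0.66 log units; beyond the scatter) may be reversed. Among the measured compounds shown here, no measured compound carries the acetyl. A modest move to a lower number in this assay is therefore expected, ending short of compound 1 or close to it. The expected size is a 2.3-fold lower number from compound 2 to compound 3 (0.35 log units; beyond the scatter). For compound 3 the estimated value is 10000 nM, with an expected range of 3500 nM to 30000 nM.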

Compound 3, half-maximal effective concentration: 12200 nM
Compound 3: middle estimate off by 1.2-fold (0.09 log units), on the low side; the measured number falls inside the stated range.
By their numbers in this assay, from the lowest: compound 1; then compounds 3 and 2 (each within the scatter of the next).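

In this assay, acetyl in place of hydroxymethyl on a saturated chain carbon, two bonds along the chain from an aromatic nitrogen, gives a 1.9-fold lower number from compound 2 to compound 3 (0.27 log units; within the scatter) and so leaves compound 2 and compound 3 indistinguishable on this read-out. The comparison with the plain propyl chain gives a 2.4-fold higher number from compound 1 to compound 3 (0.39 log units; beyond the scatter) for acetyl in place of methyl at the same place, which shows that losing the hydroxy does not on its own restore the number of compound 1, as compound 3 carries no hydrogen-bond donor on this chain and still stands apart from compound 1. Nothing in hand accounts for either step, and the chain can only be described, not explained.

Open, as far as these compounds go, is how an amine, a carboxylic acid or a longer chain at this place would read, and whether any of these would match or improve on compound 1 at 5000 nM in this assay. Also open, from the compounds shown here alone, is whether the other propyl chain on the shared core tolerates the same replacements, as all three compounds keep it unchanged.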